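Methoxy for fluoro on the nitrile-bearing ring

This account rests on a few compounds, and the source may have more. Where it says the series, first, only, none or still open, it means among the compounds named here.

Of the compounds shown here, two have been measured so far. Compound 1 `c1ccc(-c2ccc3cccnc3n2)cc1` and compound 2 `N#Cc1cc(F)cc(-c2cc3ncccc3cn2)c1` were both run in a functional assay on CHO cells for antagonist activity at metabotropic glutamate receptor 5 (Rattus norvegicus), read by calcium flux; on this read-out lower numbers stand for stronger inhibition and higher numbers for weaker inhibition. In this assay compound 1 gives 1840 nM, and compound 2 gives 1590 nM. These two numbers lie within the usual scatter of each other, so on the data in hand compound 2 cannot be set apart from compound 1, and neither can be called the more potent of the pair.

Compound 3 `COc1cc(C#N)cc(-c2cc3ncccc3cn2)c1` has not yet been run in this assay. It differs from compound 2 by methoxy in place of fluoro on an aromatic carbon. Among the compounds with values here, no pair of measured compounds shows this change, so there is nothing to lean on beyond the two numbers already given.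

The step expected in this assay is a 1.3-fold lower number from compound 2 to compound 3 (0.12 log units; within the scatter), a modest move that may not clear the scatter. Compound 3 is therefore estimated at 1200 nM, with a range from 400 nM to 3600 nM.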

Compound 3, half-maximal inhibitory concentration: 68 nM
Compound 3: the middle estimate sits 18-fold (1.25 log units) above what was measured; the measured number lies below the stated range.
By their numbers in this assay, from the lowest: compound 3; then compounds 2 and 1 (each within the scatter of the next).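

In this assay, methoxy in place of fluoro on this aromatic carbon, meta to a cyano group, gives a 23-fold lower number from compound 2 to compound 3 (1.37 log units; beyond the scatter), which shows that the number depends strongly on the group held at this position. Until now no two measured compounds differed in one place, so nothing had shown how much a single exchange could move the number on this core; this one step moves it well beyond the scatter. The exchange puts 2 heavy atoms in place of 1 and brings in 1 hydrogen-bond acceptor, but no measurement available here explains why the step is so large.

From the compounds shown here alone, whether it is the oxygen, the added carbon or the loss of fluoro that matters stays open, as does whether an ethoxy group, a hydroxyl group or an amine on the same carbon would match compound 3 at 68 nM in this assay. Also open, going by these compounds, is whether methoxy in place of fluoro would give a step of similar size at any other carbon of this ring or on a different core, such as that of compound 1.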